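A Trifluoromethoxy Swap on Compound 2

A few compounds are considered here, and "the series" means these few. Any claim that something is new, unique, unknown or untested is made for them only; others in the source may bear on it.

In a functional assay on HeLa cells (Homo sapiens) for antiproliferative activity, read by MTT assay, with a stated time of 72 h (a higher number here means a weaker inhibitor, a lower number a stronger inhibitor), compound 1 `CCNC(=O)c1cc(Oc2ccc(NC(=O)c3nn(-c4ccccc4OC(F)(F)F)c(=O)cc3C)cc2)ccn1` gives 3990 nM and compound 3 `CCNC(=O)c1cc(Oc2ccc(NC(=O)c3nn(-c4cccc(F)c4)c(=O)cc3C)cc2)ccn1` gives 6870 nM. Compound 2 `CCCNC(=O)c1cc(Oc2ccc(NC(=O)c3nn(-c4ccc(C)cc4)c(=O)cc3C)cc2F)ccn1` gives 14200 nM, the highest number of the three, and both others lie below it by more than the usual scatter of repeated measurements.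

Compound 4 `CCCNC(=O)c1cc(Oc2ccc(NC(=O)c3nn(-c4ccccc4OC(F)(F)F)c(=O)cc3C)cc2F)ccn1` has not been measured yet. It differs from compound 2 in one place, with 2-(trifluoromethoxy)phenyl in place of 4-methylphenyl on an aromatic nitrogen.

Going by the values given here, only one measured step involves this kind of change: a 1.7-fold higher number from compound 1 to compound 3 (0.24 log units; within the scatter). There, 3-fluorophenyl takes the place of 2-(trifluoromethoxy)phenyl, so the group that enters compound 4 is the one that leaves in that step. This is a thin guide, since the step is small, it does not involve 4-methylphenyl, and the rest of the molecule in that pair differs from compound 2 elsewhere too. Among the compounds with values here, no measured pair shows the exact swap.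

In this assay, no step beyond the scatter is therefore expected, with at most a slight drift toward a lower number. The estimated change is a 1.4-fold lower number from compound 2 to compound 4 (0.15 log units; within the scatter). Compound 4 is expected at about 10000 nM, with an estimated range of 4800 nM to 20000 nM.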

Compound 4, half-maximal inhibitory concentration: 3690 nM
Beside the measured number, compound 4's estimate is 2.7-fold (0.43 log units) above it; the measured number lies below the stated range.
By their numbers in this assay, from the lowest: compounds 4, 1 and 3 (each within the scatter of the next); then compound 2.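

In this assay, the group on the aromatic nitrogen turns out to move the number by more than the scatter: putting 2-(trifluoromethoxy)phenyl in place of 4-methylphenyl gives a 3.8-fold lower number from compound 2 to compound 4 (0.59 log units; beyond the scatter). Going by these compounds alone, the only earlier step at this position, a 1.7-fold higher number from compound 1 to compound 3 (0.24 log units; within the scatter), stayed within the scatter and so could not show that this position matters at all; the new step shows that it does, at least on the core of compound 2. Nothing on hand accounts for the size or direction of this step, so it stands as an observation without an explanation.

The swap changes the atoms of the group and where its substituent sits on the phenyl ring at the same time, so a plain phenyl or a 2-methoxyphenyl group on the same core would be needed to tell which part of the change goes with the lower number. From the compounds shown here alone, it also remains open whether 4-methylphenyl on the core of compound 1 would give a step of similar size, or whether this one belongs to the core of compound 2 alone.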